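A few compounds are considered here, and "the series" means these few. Any claim that something is new, unique, unknown or untested is made for them only; others in the source may bear on it.

Measured compounds:
- compound 1 `CN(C)CCNc1nc(NCc2ccco2)c2ccccc2n1`: 21.7%
- compound 2 `Cc1cccc(N2CCN(CCCCNc3nc(NCc4ccco4)c4cc(F)ccc4n3)CC2)c1C`: 96.1%

In a functional assay on HT-29 cells (Homo sapiens) for cytotoxicity, read by MTT assay, with a stated time of 2 days, tested at 10 uM (a higher number here means more inhibition at the concentration tested (going by the name of the read-out), a lower number less inhibition), compound 1 gives 21.7%, the lowest of the two numbers shown. Compound 2 gives 96.1% in this assay, a number well beyond the usual scatter above compound 1, though the two structures differ in several places at once, so no single change can be read from that gap.

Compound 3 `CCN(CC)CCNc1nc(NCc2ccco2)c2ccccc2n1` has not yet been measured in this assay. It differs from compound 1 in one place: diethylamino in place of dimethylamino on a saturated chain carbon, two bonds along the chain from a nitrogen on an aromatic ring. Two carbon atoms are added on a chain end far from the shared core, and the count of hydrogen-bond donors and acceptors stays the same. Going by the values given here, with no measured pair showing this change, the step expected from compound 1 to compound 3 in this assay is small, a number 6.3 percentage points higher from compound 1 to compound 3 (within the scatter), within the scatter, with a slight lean upward. Compound 3 is therefore estimated at 28% in this assay, in a range from 10% to 50%.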

Compound 3, a percentage reported as inhibition, at one concentration (the size of the read-out at that concentration, not a potency): 75.1%
For compound 3 the middle estimate is 47.1 percentage points below the measured one; the measured number lies above the stated range.
By their numbers in this assay, from the lowest: compound 1; then compound 3; then compound 2.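

In this assay the swap of dimethylamino for diethylamino, on a saturated chain carbon, two bonds along the chain from a nitrogen on an aromatic ring, brings a number 53.4 percentage points higher from compound 1 to compound 3 (beyond the scatter) with only that one place altered. Going by these compounds alone, this is the first comparison here that isolates a single change, and it shows that the end of this chain, far from the shared core, is not a silent position: two added carbon atoms, with the same count of hydrogen-bond donors and acceptors, are enough to move the number well past the usual scatter. Nothing available explains why the number rises this far. As far as these compounds go, whether dipropylamino or a pyrrolidine ring at the chain end would carry the number further stays open. So does what a longer chain carrying the diethylamino group would do.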